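A few compounds are considered here, and "the series" means these few. Any claim that something is new, unique, unknown or untested is made for them only; others in the source may bear on it.

Compound 1 `CCc1ccc(-c2nn3cc(-c4cccc(N)c4)nc3s2)cc1`: 6000 nM
Compound 2 `C=C(Br)C(=O)Nc1cccc(-c2cn3nc(-c4ccc(CC)cc4)sc3n2)c1`: 2200 nM
Compound 3 `C=C(Br)C(=O)Nc1cccc(-c2cn3nc(-c4ccc(F)cc4)sc3n2)c1`: 250 nM

In a functional assay on L1210 cells (Mus musculus) for inhibition, read by cell counting, with a stated time of 2 days (on this read-out lower numbers stand for stronger inhibition and higher numbers for weaker inhibition), compound 3 holds the lowest number of the three, separated from its nearest neighbour by an 8.8-fold lower number from compound 2 to compound 3 (0.94 log units; beyond the scatter) and from compound 1 by a wider gap still. Compound 4 `C=C(Br)C(=O)Nc1cccc(-c2cn3nc(Cc4cccc(OC)c4)sc3n2)c1` differs from compound 3 by 3-methoxybenzyl in place of 4-fluorophenyl on an aromatic carbon. Going by the values given here, no measured step matches this change. The step of a 2.7-fold lower number from compound 1 to compound 2 (0.44 log units; beyond the scatter) concerns another position; the step of an 8.8-fold lower number from compound 2 to compound 3 (0.94 log units; beyond the scatter) does concern this position and shows that a small exchange there already moves the number substantially. Since the present exchange is larger than that measured one, a step back toward weaker inhibition is expected for compound 4, about a 6.0-fold higher number from compound 3 to compound 4 (0.78 log units; beyond the scatter). Compound 4 is estimated at 1500 nM, within 300 nM to 8000 nM.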

Compound 4, half-maximal inhibitory concentration: 2000 nM
Compound 4: the middle estimate sits 1.3-fold (0.12 log units) below what was measured; the range from low to high includes it.
By their numbers in this assay, from the lowest: compound 3; then compounds 4 and 2 (each within the scatter of the next); then compound 1.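

In this assay, replacing 4-fluorophenyl with 3-methoxybenzyl on this aromatic carbon gives an 8.0-fold higher number from compound 3 to compound 4 (0.90 log units; beyond the scatter), so the low number of compound 3 does not carry over to this larger group. Against 4-ethylphenyl the same group gives a 1.1-fold lower number from compound 2 to compound 4 (0.04 log units; within the scatter), which leaves 4-fluorophenyl as the only one of these three groups standing apart. No evidence here explains either step.

Still open, as far as these compounds go, is how an amine or a carboxylic acid at this place would compare. Also open, from the compounds shown here alone, is whether unsubstituted phenyl or 4-chlorophenyl would stay with compound 3 or fall in with compound 2 and compound 4.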